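A few compounds are considered here, and "the series" means these few. Any claim that something is new, unique, unknown or untested is made for them only; others in the source may bear on it.

Of the compounds shown here, two have been measured in a functional assay on SK-MEL-28 cells (Homo sapiens) for inhibition, read by sulforhodamine B assay, with a stated time of 48 h (on this read-out lower numbers stand for stronger inhibition of growth and higher numbers for weaker inhibition of growth), so far. Compound 1 `N#C/C(=C\N1CCN(C(=O)c2ccco2)C1=S)C(N)=O` gives 15800 nM in this assay. Compound 2 `O=CN1CCN(c2ccc(Cl)cc2)C1=S` gives 19100 nM in this assay, the higher of the two numbers, though its gap to compound 1 lies within the scatter, so the two cannot be told apart on the present data. Compound 3 `O=CN1CCN(c2ccc(Cl)c(Cl)c2)C1=S` has not yet been measured. It differs from compound 2 by chloro in place of hydrogen on an aromatic carbon. No measured pair shows this change, so nothing in the data fixes its size or direction, and no reason is known to expect a large move either way. The expected step is a 1.3-fold lower number from compound 2 to compound 3 (0.10 log units; within the scatter), none beyond the scatter. The estimate for compound 3 in this assay is 15000 nM, with a range from 5000 nM to 45000 nM.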

Compound 3, concentration for 50% growth inhibition: 18200 nM
Estimate against measurement, compound 3: 1.2-fold (0.08 log units) below; the measured number falls inside the stated range.
By their numbers in this assay, from the lowest: compounds 1, 3 and 2 (each within the scatter of the next).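

In this assay, chloro in place of hydrogen on this aromatic carbon amounts to a 1.0-fold lower number from compound 2 to compound 3 (0.02 log units; within the scatter), the first measured size for this change. The place, ortho to a chloro group and meta to a group of 8 heavy atoms on the six-membered aromatic ring of carbon only, thus takes this added chlorine atom with no shift that can be told from the scatter. Nothing at hand explains this result.

The compounds shown leave open whether a different group at this place, such as an amine, a carboxylic acid or a longer chain, would move the number beyond the scatter. They also leave open whether chloro at the other carbons of this ring would behave in the same way.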